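The source may report more compounds than this note shows. Statements on the series, on what has been measured and on what is new or still open speak of the compounds shown alone.

Measured so far:
compound 1 `O=C(c1ccc2c(c1)OCCO2)N1N=C(c2ccccc2)CC1c1ccccc1F`, 2500 nM
compound 2 `O=C(c1ccc2c(c1)OCCO2)N1N=C(c2ccccc2)CC1c1ccc(F)cc1`, 5210 nM
compound 3 `COc1ccc(C2=NN(C(=O)c3ccc4c(c3)OCCO4)C(c3ccc(OC)cc3)C2)cc1`, 9890 nM

These three share one core and differ only in the two aryl groups on the five-membered ring. In a functional assay on WM 266-4 cells (Homo sapiens) for inhibition, read by MTT assay, with a stated time of 24 h (a higher number here means a weaker inhibitor of growth, a lower number a stronger inhibitor of growth), compound 3 gives the highest number of the three, though compound 2 sits within the scatter of it; only compound 1 is clearly apart. Compound 4 `COc1ccc(C2CC(c3ccccc3)=NN2C(=O)c2ccc3c(c2)OCCO3)cc1` is obtained from compound 3 by hydrogen in place of methoxy on an aromatic carbon. Within the data shown here, no measured step removes a methoxy; the only single-point step, a 2.1-fold higher number from compound 1 to compound 2 (0.32 log units; beyond the scatter), moved a fluorine on the other aryl ring and was modest. Since compound 2 and compound 3 already sit close together, compound 4 is expected to land between them, with a 1.4-fold lower number from compound 3 to compound 4 (0.15 log units; within the scatter), within the scatter. The estimate for compound 4 is 7000 nM, ranging from 3000 nM to 16000 nM.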

Compound 4, concentration for 50% growth inhibition: 8370 nM
Beside the measured number, compound 4's estimate is 1.2-fold (0.08 log units) below it, and the stated range covers the measured number.
By their numbers in this assay, from the lowest: compound 1; then compounds 2, 4 and 3 (each within the scatter of the next).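

In this assay, hydrogen in place of methoxy on this aromatic carbon changes little (a 1.2-fold lower number from compound 3 to compound 4 (0.07 log units; within the scatter)), so this 4-methoxyphenyl to phenyl change leaves the number within the scatter. On the other aryl ring, methoxy in place of fluoro also stays within the scatter (a 1.6-fold higher number from compound 2 to compound 4 (0.21 log units; within the scatter)), while 4-methoxyphenyl in place of 2-fluorophenyl gives a modest step beyond it (a 3.3-fold higher number from compound 1 to compound 4 (0.52 log units; beyond the scatter)). No available evidence explains these results. From the compounds shown here alone, whether an amine or a carboxylic acid on this aromatic carbon would shift growth inhibition remains open.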